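Adding a Chloro Group to Compound 3

The compounds below may be only part of what the source reports. "The series", "measured", "known", "first", "only" and "open" are said of these compounds alone.

Four compounds sharing one core were examined for cytotoxicity. In a functional assay on MCF7 cells (Homo sapiens) for cytotoxicity, read by sulforhodamine B assay, with a stated time of 48 h (on this read-out lower numbers stand for stronger inhibition and higher numbers for weaker inhibition), compound 3 `C=CCOc1ccc(Cl)cc1C(=O)c1cccnc1` gives 54000 nM. Compound 2 `O=C(c1cccnc1)c1cc(Cl)cc(Cl)c1O` gives 29600 nM in this assay, and the two values lie within the usual scatter of each other, so neither can be ranked over the other. Compound 1 `C=CCOc1c(Cl)cccc1C(=O)c1cccnc1` gives > 100000 nM, which is a limit of the assay and not a number. For the measured compounds named here, compound 3 therefore stands level with the only other compound that has a true number.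

The next compound to be measured is compound 4 `C=CCOc1c(Cl)cc(Cl)cc1C(=O)c1cccnc1`. It differs from compound 3 in a single place: chloro in place of hydrogen on an aromatic carbon, with the chloro group ortho to the allyloxy group and meta to the existing chloro group.

Going by the values given here, no measured step isolates this change, so the estimate rests on the values of the three measured compounds. Neither a large gain nor a large loss in this assay is expected, and any change is expected to stay within the scatter or only slightly beyond it, in either direction. The expected step is a 1.2-fold lower number from compound 3 to compound 4 (0.08 log units; within the scatter). The estimated value for compound 4 is 45000 nM, with an expected range of 18000 nM to 100000 nM.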

Compound 4, half-maximal inhibitory concentration: 85000 nM
The estimate for compound 4 lay 1.9-fold (0.28 log units) below the measured number, and the stated range covers the measured number.
By their numbers in this assay, from the lowest: compounds 2, 3 and 4 (each within the scatter of the next, the first and the last beyond it). At a limit, above all of these: compound 1.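

Chloro in place of hydrogen at this place, ortho to the allyloxy group, comes with a 1.6-fold higher number from compound 3 to compound 4 (0.20 log units; within the scatter), so in this assay the second chloro group brings no change that can be told from the scatter. Allyl in place of hydrogen on the oxygen, with both chloro groups present, comes with a 2.9-fold higher number from compound 2 to compound 4 (0.46 log units; beyond the scatter), the only step here beyond the scatter, and a modest one, so the group on the oxygen shows a clearer difference in this pair than the added chloro group does in the step before. Compound 1 stands at a limit and not at a number, so an at least 1.1-fold lower number from compound 1 to compound 4 (0.07 log units; that floor lies within the scatter) gives only a floor: the limit of > 100000 nM in this assay, at which 1 of the 4 values shown sits.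

The compounds shown carry only hydrogen or chloro at this place, which leaves open whether a methoxy group, an amine or a longer chain there would move the number beyond the scatter. As far as these compounds go, it is also open how a propyl chain or a carboxylic acid on the oxygen would compare with the allyl group and with hydrogen.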